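This account rests on a few compounds, and the source may have more. Where it says the series, first, only, none or still open, it means among the compounds named here.

Two compounds from this series already have numbers. Compound 1 `COc1ccc(/C=C/C(=O)c2cc(-c3cc(OC)c(OC)c(OC)c3)n3nc(-c4ccccc4)cc3n2)cc1OC` and compound 2 `COc1cc(-c2cc(/C=C/C(=O)c3ccc(C)c(C)c3)nc3cc(-c4ccccc4)nn23)cc(OC)c1OC` share the same fused core carrying a 3,4,5-trimethoxyphenyl group and a phenyl group, and differ in the side arm attached to the core. In a functional assay on DU-145 cells (Homo sapiens) for antiproliferative activity, read by MTT assay, with a stated time of 24 h (on this read-out higher numbers stand for weaker inhibition and lower numbers for stronger inhibition), compound 1 gives 15300 nM, and in this assay compound 2 gives 15400 nM; the two numbers lie within the scatter of each other, so neither can be called the stronger of the pair. Compound 3 `COc1ccc(/C=C/C(=O)c2cc(-c3cc(OC)c(OC)c(OC)c3)n3nc(-c4ccccc4)cc3n2)cc1` has not yet been measured. It differs from compound 2 by (2-(4-methoxyphenyl)ethenyl)carbonyl in place of 2-((3,4-dimethylphenyl)carbonyl)ethenyl on an aromatic carbon. Both arms hold the same count of heavy atoms around an aromatic ring and a carbonyl, and compound 1 with a related arm gave 15300 nM, so the step from compound 2 to compound 3 is expected to stay within the scatter, as a 1.0-fold lower number from compound 2 to compound 3 (0.01 log units; within the scatter). Compound 3 is therefore estimated at 15000 nM, within a range from 5000 nM to 45000 nM.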

Compound 3, half-maximal inhibitory concentration: 16900 nM
The estimate for compound 3 lay 1.1-fold (0.05 log units) below the measured number, within the range that was stated.
By their numbers in this assay, from the lowest: compounds 1, 2 and 3 (each within the scatter of the next).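

In this assay the swap of 2-((3,4-dimethylphenyl)carbonyl)ethenyl for (2-(4-methoxyphenyl)ethenyl)carbonyl gives a 1.1-fold higher number from compound 2 to compound 3 (0.04 log units; within the scatter) and so does not separate these two arms, even though the arm is joined to the core through its ethenyl end in one and its carbonyl end in the other. Hydrogen in place of one methoxy on the arm's aromatic ring gives a 1.1-fold higher number from compound 1 to compound 3 (0.04 log units; within the scatter) and shows that this methoxy can go without a step beyond the scatter. No measurement is available that could explain these results. Going by these compounds, whether an amine or a carboxylic acid on that aromatic ring would give a step beyond the scatter remains open. Compound 2 also differs from compound 3 in both the ring groups and the arm's direction, so the contribution of each stays unresolved.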